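Allyl Thiourea Replaces Methyl Isothiourea on a Shortened Chain

The compounds below may be only part of what the source reports. "The series", "measured", "known", "first", "only" and "open" are said of these compounds alone.

Compound 1 `C/N=C(\S)NCCCCCn1nc(-c2ccccc2)ccc1=O` has the highest number of the three measured compounds in a functional assay on the whole organism with Rattus norvegicus as the target, at a dose of 100 mg/kg (a higher number here means more inhibition at the dose given (going by the name of the read-out), a lower number less inhibition), giving 68.9%. Compound 2 `CCC/N=C(/NC#N)NCCCn1nc(-c2ccccc2)ccc1=O` gives 52.9%, and compound 3 `CCC/N=C(/NC#N)NCCCn1nc(C)ccc1=O` gives 17.5%. Within the data shown here, the only step between two compounds that differ in one place is a number 35.4 percentage points lower from compound 2 to compound 3 (beyond the scatter), and that step touches the phenyl on the shared core rather than the side chain.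

Compound 4 `C=CCNC(=S)NCCCCn1nc(-c2ccccc2)ccc1=O` differs from compound 1 in the side chain: a group of 7 heavy atoms (4 carbon, 2 nitrogen, 1 sulfur; no ring) in place of a group of 6 heavy atoms (3 carbon, 2 nitrogen, 1 sulfur; no ring), on a saturated chain carbon, four bonds along the chain from an aromatic nitrogen. Among the measured compounds shown here, no measured step bears on this change. Compound 2 keeps the same phenyl as compound 1 but differs from it in its chain and terminal group; compound 2 gives 52.9%, whereas compound 1 gives 68.9%, and the two numbers show that such alterations can shift the read-out beyond the scatter without erasing inhibition. Because compound 1 gives 68.9% and the phenyl that carries the large a number 35.4 percentage points lower from compound 2 to compound 3 (beyond the scatter) is retained, compound 4 is expected to keep a substantial share of that inhibition. Compound 4 is therefore estimated at 58%, in the range 35% to 78%, which is expected to mean a step of a number 10.9 percentage points lower from compound 1 to compound 4 (beyond the scatter).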

Compound 4, a percentage reported as inhibition, in the whole organism at one dose (the size of the read-out at that dose, not a potency): 27.1%
Beside the measured number, compound 4's estimate is 30.9 percentage points above it, outside the stated range (below it).
By their numbers in this assay, from the lowest: compounds 3 and 4 (each within the scatter of the next); then compound 2; then compound 1.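

The side chain proves to be a position that counts in its own right: in this assay, exchanging the group of 6 heavy atoms for the group of 7 heavy atoms gives a number 41.8 percentage points lower from compound 1 to compound 4 (beyond the scatter), a large step. Among these compounds, the only step available before this one concerned the phenyl on the shared core, and that left open whether retaining the phenyl would be enough to keep inhibition at this dose; with the phenyl unchanged here, the result shows that it is not, and that a change on a saturated chain carbon, four bonds along the chain from an aromatic nitrogen, can by itself take away much of the read-out. Nothing available here accounts for this loss of inhibition.

From the compounds shown here alone, the step treats the exchanged group as a whole, so how much of it belongs to the length of the chain and how much to the terminal group remains open. Also open, going by these compounds, is how a longer chain carrying the same terminal group, or an amine at the end of the chain, would read in this assay.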